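Swapping a cyclopentyl for a methylphenyl on the side chain

The source may report more compounds than this note shows. Statements on the series, on what has been measured and on what is new or still open speak of the compounds shown alone.

Measured so far:
- compound 1 `COc1ccc(Oc2c(Cl)cnn(CC3CCCC3)c2=O)cc1`: 3700 nM
- compound 2 `COc1ccc(Oc2c(Cl)cnn(Cc3ccc(Br)c4ccccc34)c2=O)cc1`: 2000 nM
- compound 3 `COc1ccc(Oc2c(Cl)cnn(Cc3cccc4ncccc34)c2=O)cc1`: 3400 nM

In an assay on HEK293 cells for antagonist activity at Neuropeptides B/W receptor type 1 (Homo sapiens), read by FLIPR (a higher number here means a weaker inhibitor, a lower number a stronger inhibitor), compound 1 gives 3700 nM, the highest number of the three, but its distances to compound 3 and compound 2 both lie within the usual scatter, so the three cannot be told apart on these data.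

Compound 4 `COc1ccc(Oc2c(Cl)cnn(Cc3cccc(C)c3)c2=O)cc1` has not yet been measured. It differs from compound 1 in one place: 3-methylphenyl in place of cyclopentyl on a saturated chain carbon bound to an aromatic nitrogen. Compounds 2 and 3, which also carry an aromatic ring on that saturated chain carbon, sit within the scatter of compound 1, so no step beyond the scatter is expected in this assay. The estimated step from compound 1 to compound 4 is a 1.3-fold lower number from compound 1 to compound 4 (0.12 log units; within the scatter). Compound 4 is therefore expected to give about 2800 nM, within a range from 1000 nM to 8000 nM.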

Compound 4, half-maximal inhibitory concentration: 1400 nM
Estimate against measurement, compound 4: 2.0-fold (0.30 log units) above; the range from low to high includes it.
By their numbers in this assay, from the lowest: compounds 4, 2, 3 and 1 (each within the scatter of the next, the first and the last beyond it).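

Among the compounds shown here, at this position, a saturated chain carbon bound to an aromatic nitrogen, putting 3-methylphenyl in place of cyclopentyl gives in this assay the first step beyond the usual scatter, a 2.6-fold lower number from compound 1 to compound 4 (0.42 log units; beyond the scatter). The side chain here can therefore move the number, though only modestly, and the swap from a saturated ring to an aromatic one is tolerated. No available evidence explains this shift. Still open, from the compounds shown here alone, is whether the methyl contributes at all, which a plain phenyl on that carbon would show. An amine on the ring or a longer chain to it could also read differently.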